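Swapping a piperidine for a tetrahydroquinoline: solubility outlook

The compounds below may be only part of what the source reports. "The series", "measured", "known", "first", "only" and "open" are said of these compounds alone.

Measured so far:
compound 1 `COc1ccc2[nH]c(C(=O)N3CC(=O)N(Cc4ccccc4)[C@@H](CN4CCCCC4)C3)cc2c1` — > 25000 nM
compound 2 `COc1ccc2[nH]c(C(=O)N3CC(=O)N(Cc4cccc(OC(F)F)c4)[C@@H](CN4CCC(C#N)CC4)C3)cc2c1` — 27900 nM

In a physicochemical assay for solubility, read by spectrophotometry, in phosphate buffer, with a stated time of 2 h, at pH 7.4 (a higher number here means a more soluble compound, a lower number a less soluble compound), compound 1 reports > 25000 nM, which is a limit of the assay rather than a number. Compound 1 therefore stands at the limit of > 25000 nM in this assay, at which 1 of the 2 values shown sits. In this assay compound 2 gives 27900 nM. For the measured compounds named here, no step between two measured compounds is available. Compound 3 `COc1ccc2[nH]c(C(=O)N3CC(=O)N(Cc4ccccc4)[C@@H](CN4CCCc5ccccc54)C3)cc2c1` differs from compound 1 by 1,2,3,4-tetrahydroquinolin-1-yl in place of piperidin-1-yl on a saturated chain carbon bound to a saturated ring carbon. For this change a step of moderate size towards lower solubility is expected, an at least 2.7-fold lower number from compound 1 to compound 3 (0.44 log units; beyond the scatter). Compound 3 is estimated at 9000 nM, within 2500 nM to 25000 nM.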

Compound 3, solubility: 8500 nM
Compound 3: middle estimate off by 1.1-fold (0.02 log units), on the high side; the measured number falls inside the stated range.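

In this assay compound 1 gives > 25000 nM as a limit of the assay and not a number. For the compounds shown here, putting 1,2,3,4-tetrahydroquinolin-1-yl in place of piperidin-1-yl on a saturated chain carbon bound to a saturated ring carbon gives an at least 2.9-fold lower number from compound 1 to compound 3 (0.46 log units; beyond the scatter) as the first step that can be read at this place. This change, which adds an aromatic ring of carbon only, thus goes with a step beyond the scatter, but only its minimum size can be read.

As far as these compounds go, whether morpholin-4-yl, or a tetrahydroquinoline carrying a carboxylic acid, would give a higher or lower number at this place stays open.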